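A few compounds are considered here, and "the series" means these few. Any claim that something is new, unique, unknown or untested is made for them only; others in the source may bear on it.

Measured compounds in this series:

compound 1 `CC1CCN(c2nc(C(F)(F)F)ccc2CNC(=O)Nc2cccc3c2ccc(=O)n3C)CC1`; in an assay on CHO cells for agonist activity at transient receptor potential cation channel subfamily V member 1 (Homo sapiens) (on this read-out lower numbers stand for an effect already at smaller amounts and higher numbers for an effect only at larger amounts of compound), compound 1 gives "not active" (no number reported).
compound 2 `CC1CCN(c2nc(C(F)(F)F)ccc2CNC(=O)Nc2ccc3ccc(=O)[nH]c3c2)CC1`; in this assay compound 2 gives "not active" (no number reported).
compound 3 `CCCN(CCC)c1nc(C(F)(F)F)ccc1CNC(=O)Nc1cccc2c(=O)[nH]ccc12`; in this assay compound 3 gives 2.79 nM.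

Compound 3 is the only one of the three that comes back with a number in this assay; compounds 1 and 2 return no number at all, so no order among the three can be drawn from the values alone, and compound 3 simply stands as the single quantified point. Among the measured compounds shown here, compounds 1 and 2 each differ from compound 3 in more than one place, so no single-change step between measured compounds is available.

Compound 4 `O=C(NCc1ccc(C(F)(F)F)nc1OCC1CCCC1)Nc1cccc2c(=O)[nH]ccc12` keeps the rest of compound 3 and changes one group: cyclopentylmethoxy in place of dipropylamino on an aromatic carbon. For the measured compounds named here, with no measured step to lean on, the expectation rests on compound 3 alone, at 2.79 nM, and on the fact that the group entering is of the same heavy-atom count as the one leaving. A shift somewhat beyond the scatter, toward an effect only at larger amounts, is expected rather than none: a 2.9-fold higher number from compound 3 to compound 4 (0.46 log units; beyond the scatter). Compound 4 is accordingly estimated at 8 nM, with a range from 2 nM to 40 nM.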

Compound 4, half-maximal effective concentration: 15.5 nM
For compound 4 the middle estimate is 1.9-fold (0.29 log units) below the measured one; measured number inside the range.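

Among the compounds shown here, this is the first single-change step: on an aromatic carbon next to the ring nitrogen, with the trifluoromethyl group unchanged, cyclopentylmethoxy in place of dipropylamino gives a 5.6-fold higher number from compound 3 to compound 4 (0.74 log units; beyond the scatter) in this assay. The position therefore still returns a number without dipropylamino, although the step is modest and lies beyond the scatter. The two groups match in heavy-atom, donor and acceptor counts, yet they differ both in the attached atom, oxygen against nitrogen, and in the five-membered non-aromatic ring against open chains, and no measurement on hand ties the step to either difference.

A cyclopentylmethylamino group, which keeps the ring and restores the nitrogen, or a propoxy chain, which keeps the oxygen and drops the ring, would separate the two differences at this position. Compound 1 and compound 2 each differ from compound 3 in more than one place, so the absence of a number for them cannot yet be assigned to any single part of their structures.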